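From pyridine to methylthiophene on the outer ring

A few compounds are considered here, and "the series" means these few. Any claim that something is new, unique, unknown or untested is made for them only; others in the source may bear on it.

Three compounds share one core and differ only in the outermost ring:
compound 1, `Cc1ccc(-c2ccc(-c3nc4ccc(S(C)(=O)=O)cc4[nH]3)cc2)cc1`, gives > 20000 nM in an assay on isolated protein for inhibition of acyl-CoA desaturase 1 (Rattus norvegicus) (on this read-out lower numbers stand for stronger inhibition and higher numbers for weaker inhibition), which is a limit of the assay and not a number.
compound 2, `CS(=O)(=O)c1ccc2nc(-c3ccc(-c4ccccc4O)cc3)[nH]c2c1`, gives 336 nM.
compound 3, `CS(=O)(=O)c1ccc2nc(-c3ccc(-c4ccncc4)cc3)[nH]c2c1`, gives 2470 nM.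

Compound 3 therefore holds the highest of the two real numbers. Its nearest neighbour is compound 2: a 7.4-fold higher number from compound 2 to compound 3 (0.87 log units; beyond the scatter). Compound 1 offers only a bound, (the limit of > 20000 nM in this assay, at which 1 of the 3 values shown sits), so the step of an at least 8.0-fold lower number from compound 1 to compound 3 (0.90 log units; beyond the scatter) is known only in one direction.

Compound 4, `Cc1ccsc1-c1ccc(-c2nc3ccc(S(C)(=O)=O)cc3[nH]2)cc1`, is the next step: 3-methylthiophen-2-yl in place of pyridin-4-yl on an aromatic carbon. Both known swaps at this position were modest or larger, and the new ring, a 3-methylthiophen-2-yl, carries a methyl like the 4-methylphenyl of compound 1 rather than the hydroxyl of compound 2. Compound 4 is therefore expected to drift back toward a higher number, with the step of a 3.2-fold higher number from compound 3 to compound 4 (0.51 log units; beyond the scatter) as the estimate. The estimated value for compound 4 is 8000 nM, within a range from 2000 nM to 30000 nM, and a real chance remains that only a limit is reported.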

Compound 4, half-maximal inhibitory concentration: 472 nM
Beside the measured number, compound 4's estimate is 17-fold (1.23 log units) above it; the whole stated range lies above it.
By their numbers in this assay, from the lowest: compounds 2 and 4 (each within the scatter of the next); then compound 3. At a limit, above all of these: compound 1.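

In this assay, the outer ring turns out not to need a hydroxyl to reach a low number: the swap gives a 1.4-fold higher number from compound 2 to compound 4 (0.15 log units; within the scatter), so 3-methylthiophen-2-yl and 2-hydroxyphenyl cannot be told apart on this read-out. Set in place of pyridin-4-yl, the same ring gives a 5.2-fold lower number from compound 3 to compound 4 (0.72 log units; beyond the scatter), which shows that a five-membered ring with sulfur is accepted at this position and can do better than a six-membered ring with nitrogen. Carrying a methyl does not settle the outcome either, for compound 1 also has a methyl on its outer ring, yet the change of ring gives an at least 42-fold lower number from compound 1 to compound 4 (1.62 log units; beyond the scatter), a step read against a limit and not a number: the limit of > 20000 nM in this assay, at which 1 of the 4 values shown sits.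

From the compounds shown here alone, what the methyl on the thiophene contributes by itself stays open, and a plain thiophen-2-yl would speak to that. Also open, going by these compounds, is how this position responds to other groups on the outer ring, such as a methoxy in place of the hydroxyl of compound 2, or an amine.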